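This account rests on a few compounds, and the source may have more. Where it says the series, first, only, none or still open, it means among the compounds named here.

Measured so far in a functional assay on MGC-803 cells (Homo sapiens) for inhibition, read by CCK-8 assay, with a stated time of 48 h (a higher number here means a weaker inhibitor, a lower number a stronger inhibitor), are these compounds:
- Compound 1 `COc1ccc(CN(C(=O)CSC(=S)N2CCN(C)CC2)c2cc(OC)c(OC)c(OC)c2)cc1` gives 1280 nM in this test
- Compound 2 `COc1ccc(CN(C(=O)CSC(=S)N2CCN(C(C)=O)CC2)c2cc(OC)c(OC)c(OC)c2)cc1` gives 480 nM in this test
- Compound 3 `COc1ccc(CN(C(=O)CSC(=S)N2CCOCC2)c2cc(OC)c(OC)c(OC)c2)cc1` gives 2370 nM in this test

Compound 3 cannot be separated from its nearest neighbour, since the data show a 1.9-fold higher number from compound 1 to compound 3 (0.27 log units; within the scatter) and no more. Among the compounds with values here, only one compound stands clear of it, with a 4.9-fold higher number from compound 2 to compound 3 (0.69 log units; beyond the scatter) as the measured gap.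

The next compound, compound 4 `COc1ccc(CN(C(=O)CN2CCN(C(C)=O)CC2)c2cc(OC)c(OC)c(OC)c2)cc1`, carries a bigger change: a group of 9 heavy atoms (6 carbon, 2 nitrogen, 1 oxygen; one six-membered non-aromatic ring with 2 hetero atoms) in place of a group of 9 heavy atoms (5 carbon, 1 nitrogen, 1 oxygen, 2 sulfur; one six-membered non-aromatic ring with 2 hetero atoms), on a saturated chain carbon bound to a carbonyl carbon. Within the data shown here, two measured steps touch on the incoming 4-acetylpiperazin-1-yl group. One is the gap just given, and the other is a 2.7-fold lower number from compound 1 to compound 2 (0.43 log units; beyond the scatter), both modest. Both point to a lower number, but in both the group sits on a thiocarbonyl carbon. Among the measured compounds shown here, in compound 4 it sits on a saturated chain carbon bound to a carbonyl carbon, and no measured compound shows that attachment. The effect of removing the thiocarbonyl piece is therefore unknown and could cancel the hint.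

On balance, no step beyond the scatter is expected in this assay. The estimated step is a 1.3-fold higher number from compound 3 to compound 4 (0.10 log units; within the scatter) and it is held loosely. For compound 4 the estimated value is 3000 nM with an expected range of 600 nM to 15000 nM in repeated measurements.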

Compound 4, half-maximal inhibitory concentration: 12800 nM
The estimate for compound 4 lay 4.3-fold (0.63 log units) below the measured number; measured number inside the range.
By their numbers in this assay, from the lowest: compound 2; then compounds 1 and 3 (each within the scatter of the next); then compound 4.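

In this assay, the clearest reading comes from the pair that keeps the 4-acetylpiperazin-1-yl group and loses the sulfur-bearing thiocarbonyl piece, leaving that group on a saturated chain carbon bound to a carbonyl carbon: the change gives a 27-fold higher number from compound 2 to compound 4 (1.43 log units; beyond the scatter) and is the largest step in the series. The two steps that also change the ring group, a 10-fold higher number from compound 1 to compound 4 (1.00 log units; beyond the scatter) and a 5.4-fold higher number from compound 3 to compound 4 (0.73 log units; beyond the scatter), point the same way. Compound 4 is therefore the weakest of the four in this assay, and losing the thiocarbonyl piece counts for more here than any swap of ring group on the thiocarbonyl carbon.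

No measurement shown explains this loss of activity. As far as these compounds go, it remains open whether the chain sulfur or the thiocarbonyl matters more, which a simple thioether link or a carbamate link could help separate, and whether 4-methylpiperazin-1-yl or morpholin-4-yl on the same saturated chain carbon would keep the order seen on the thiocarbonyl carbon.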